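Pyridine Amide in Place of Cyanophenyl: Cytotoxicity Outlook

The source may hold more compounds than are shown below. What is called first, only, known or untested is meant among the compounds shown, and "the series" means these compounds.

Compound 1 `COc1ccc(-c2cnc(NC(=O)c3cccc([N+](=O)[O-])c3)n2C)cc1` gives > 100000 nM in a toxicity assay on THP-1 cells (Homo sapiens) for inhibition (a higher number here means that more compound is tolerated, a lower number that less compound is tolerated), a limit of the assay.
Compound 2 `Cc1cccc(C(=O)Nc2ncc(-c3ccccc3)n2C)c1` gives > 50000 nM in this assay, a limit.
Compound 3 `COc1ccc(-c2cnc(NC(=O)c3cccc(C#N)c3)n2C)cc1` gives > 100000 nM in this assay, a limit.

Compound 3 thus stands at the upper limit in this assay, as do the two other values shown. Among the measured compounds shown here, the step that the two limits leave unreadable from compound 1 to compound 3 is not readable because both compounds sit at the limit of > 100000 nM in this assay, at which 2 of the 3 values shown sit, and compound 2 sits at the limit of > 50000 nM in this assay, at which 1 of the 3 values shown sits, so no measured step gives a size to go on. Compound 4 `COc1ccc(-c2cnc(NC(=O)c3ccccn3)n2C)cc1` differs from compound 3 in one place: pyridin-2-yl in place of 3-cyanophenyl on a carbonyl carbon. With every neighbour tolerated up to its limit, compound 4 is expected to stay there too, and the step of a number no higher from compound 3 to compound 4 (the limit leaves the size open) is expected to be none beyond the scatter. For compound 4 the estimate in this assay is 100000 nM, ranging from 30000 nM to 300000 nM.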

Compound 4, half-maximal cytotoxic concentration: > 100000 nM
Compound 4 gave a limit, no number (the forecaster's own chance of this, stated with the estimate: 75%); the middle value sits exactly at the limit.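

Compound 3 and compound 4 both stand at a limit of the assay, so no step can be read between them: the limit of > 100000 nM in this assay, at which 3 of the 4 values shown sit.

The compounds shown leave open whether pyridin-2-yl and 3-cyanophenyl differ at all in this assay, and at what concentration any of these compounds stops being tolerated.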